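The compounds below may be only part of what the source reports. "The series", "measured", "known", "first", "only" and "open" are said of these compounds alone.

Compound 1, with the structure `Fc1ccc(C2=NN(c3ccccc3)C(c3cn(-c4ccccc4)nc3-c3ccc(Cl)c(Cl)c3)C2)cc1`, was measured in a functional assay on the whole organism (strain Wistar) for inhibition, with Rattus norvegicus as the target, read by paw edema, with a stated time of 30 min, at a dose of 50 mg/kg by the oral route (on this read-out higher numbers stand for more inhibition at the one dose given (going by the name of the read-out) and lower numbers for less inhibition), where compound 1 gives 44.7%. Among the compounds with values here, the only other measured compound, compound 2 with the structure `Fc1ccc(C2=NNC(c3cn(-c4ccccc4)nc3-c3ccc(Cl)c(Cl)c3)C2)cc1`, gives in this assay 45.7%, so that the two values lie within the scatter of each other; the one measured step, a number 1 percentage points higher from compound 1 to compound 2 (within the scatter), concerns hydrogen in place of phenyl on an amine nitrogen in a ring and shows no movement beyond the scatter. Within the data shown here, compound 1 thus stands within the scatter of the only other number at hand.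

The step to compound 3, with the structure `Cc1ccc(C2=NN(c3ccccc3)C(c3cn(-c4ccccc4)nc3-c3ccc(Cl)c(Cl)c3)C2)cc1`, is of a different kind: methyl in place of fluoro on an aromatic carbon. Among the measured compounds shown here, no measured step touches the group on this aromatic carbon, so nothing among the measured compounds speaks for a movement in either direction, and the one step that is known was itself within the scatter. The account therefore expects compound 3 to come out close to compound 1, with a step of about a number 0.3 percentage points higher from compound 1 to compound 3 (within the scatter). For compound 3 in this assay the estimate is 45%, between 33% and 57%.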

Compound 3, a percentage reported as inhibition, in the whole organism at one dose (the size of the read-out at that dose, not a potency): 46.8%
Compound 3: the middle estimate sits 1.8 percentage points below what was measured, within the range that was stated.
By their numbers in this assay, from the lowest: compounds 1, 2 and 3 (each within the scatter of the next).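

In this assay, within the data shown here, the change from 4-fluorophenyl to 4-methylphenyl gives the first measured reading for this aromatic carbon, para to a large group: a number 2.1 percentage points higher from compound 1 to compound 3 (within the scatter). Methyl in place of fluoro, one heavy atom for one with no hydrogen-bond donors or acceptors on either side, therefore shows no movement beyond the scatter at this position, and the same holds at the ring nitrogen, where the step reads a number 1 percentage points higher from compound 1 to compound 2 (within the scatter). No measurement at hand bears on why the fluoro and methyl compounds read alike at this one dose.

What the compounds shown leave open is whether the number at this position would move with a group of a different kind, such as an amine, a carboxylic acid or a longer chain like butyl, since fluoro and methyl are the only two groups seen there. From the compounds shown here alone, it also remains open how methyl on this aromatic carbon would read together with hydrogen on the ring nitrogen, and how either change would read at other doses or times.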